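The compounds below may be only part of what the source reports. "The series", "measured", "known", "first", "only" and "open" are said of these compounds alone.

Measured so far:
- compound 1, `COc1ncnc2c1c(-c1ccoc1)cn2[C@@H]1O[C@H](CO)[C@@H](O)[C@H]1O`: 110 nM
- compound 2, `COc1ncnc2c1c(-c1cccs1)cn2[C@@H]1O[C@H](CO)[C@@H](O)[C@H]1O`: 80 nM

In a functional assay on HCT-116 cells (Homo sapiens), read by MTT assay, with a stated time of 72 h (on this read-out lower numbers stand for stronger inhibition and higher numbers for weaker inhibition), compound 1 gives 110 nM and compound 2 gives 80 nM. Compound 2 stands at the smaller of the two numbers, but the step of a 1.4-fold lower number from compound 1 to compound 2 (0.14 log units; within the scatter) lies within the scatter, so the two compounds cannot be told apart on these data.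

Compound 3, `CSc1ncnc2c1c(-c1cccs1)cn2[C@@H]1O[C@H](CO)[C@@H](O)[C@H]1O`, has not yet been measured. It differs from compound 2 by methylsulfanyl in place of methoxy on an aromatic carbon. Going by the values given here, no measured step touches this position: the only step known, a 1.4-fold lower number from compound 1 to compound 2 (0.14 log units; within the scatter), concerns a thiophen-2-yl in place of furan-3-yl, a different place on the shared core, and it was itself within the scatter. There is therefore no measured basis for expecting a step beyond the scatter in either direction, and the plain expectation is a number close to that of compound 2.

Compound 3 is thus estimated to give about 100 nM in this assay, most likely between 40 nM and 300 nM. That estimate means an expected step of a 1.3-fold higher number from compound 2 to compound 3 (0.10 log units; within the scatter), which is expected to stay within the scatter.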

Compound 3, half-maximal inhibitory concentration: > 20000 nM
Compound 3: a limit, no number; the forecaster's own chance of this, stated with the estimate: 3%; middle value at least 200-fold (2.30 log units) from the limit.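

In this assay, replacing methoxy with methylsulfanyl on the aromatic carbon next to the ring nitrogen gives an at least 250-fold higher number from compound 2 to compound 3 (2.39 log units; beyond the scatter), so the group at this position can decide whether the compound shows any measurable inhibition in these cells. The reading for compound 3 is a limit of the assay and not a number: the limit of > 20000 nM in this assay, at which 1 of the 3 values shown sits. Going by these compounds alone, the only earlier step, a 1.4-fold lower number from compound 1 to compound 2 (0.14 log units; within the scatter), concerned a different place on the shared core and stayed within the scatter, whereas this change exchanges only oxygen for sulfur, and the two groups have equal counts of heavy atoms, hydrogen-bond donors and hydrogen-bond acceptors, so those counts alone do not predict the outcome here.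

The compounds shown do not reveal why the change has so large an effect, or how an amine, a plain methyl group or a longer chain such as ethoxy would fare at this position. They also leave open whether methylsulfanyl would have the same effect with furan-3-yl in place of thiophen-2-yl, since only one such pairing appears here.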